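Compound 3 and its mirror image, compound 4

The source may report more compounds than this note shows. Statements on the series, on what has been measured and on what is new or still open speak of the compounds shown alone.

In a functional assay on HeLa cells (Homo sapiens) for antiproliferative activity, with a stated time of 48 h (a higher number here means a weaker inhibitor, a lower number a stronger inhibitor), compound 1 `Cc1cc(=O)c2c(O)cc(OCC3CO3)cc2o1` gives 17700 nM, compound 2 `Cc1cc(=O)c2c(O)cc(OC[C@H]3CO3)cc2o1` gives 16700 nM and compound 3 `Cc1cc(=O)c2c(OC[C@H]3CO3)cc(OC[C@H]3CO3)cc2o1` gives 11400 nM. These three values lie within the scatter of one another, so compound 3 stands apart from neither neighbour. Compound 4 `Cc1cc(=O)c2c(OC[C@@H]3CO3)cc(OC[C@@H]3CO3)cc2o1` is built from the same atoms and bonds as compound 3: the two compounds have the same atoms and bonds and differ only in configuration as drawn: 2 of 2 stereo elements differ (all stereocentres are inverted: mirror images); a stereocentre at a saturated ring carbon is drawn R in compound 3 and S in compound 4; a stereocentre at a saturated ring carbon is drawn R in compound 3 and S in compound 4. The closest measured evidence is a 1.1-fold lower number from compound 1 to compound 2 (0.03 log units; within the scatter), where a stereocentre drawn without a configuration becomes R, and this step is within the scatter. The step of a 1.5-fold lower number from compound 2 to compound 3 (0.17 log units; within the scatter), which puts (oxiran-2-yl)methyl in place of hydrogen, is also within the scatter. For the measured compounds named here, no compound drawn S has been measured, so the evidence is thin, and no step beyond the scatter is expected in this assay. The estimate amounts to an expected 1.1-fold higher number from compound 3 to compound 4 (0.02 log units; within the scatter). For compound 4 the expected value is 12000 nM, with an estimated range of 6000 nM to 24000 nM.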

Compound 4, half-maximal inhibitory concentration: 21700 nM
Estimate against measurement, compound 4: 1.8-fold (0.26 log units) below; the measured number falls inside the stated range.
By their numbers in this assay, from the lowest: compounds 3, 2, 1 and 4 (each within the scatter of the next).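

Inverting both stereocentres of the (oxiran-2-yl)methyl groups gives a 1.9-fold higher number from compound 3 to compound 4 (0.28 log units; within the scatter), so a full swap from R to S stays inside the scatter in this assay. The earlier pair only set R against an undefined drawing, whereas this is the first direct test of R against S, and it is a clean one: the fact that compounds 3 and 4 differ only in the configuration as drawn

The compounds shown leave open whether a single S (oxiran-2-yl)methyl group, with the other oxygen still carrying hydrogen, would behave alike. They also leave open what an amine or a longer chain would give in place of (oxiran-2-yl)methyl.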